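The source may hold more compounds than are shown below. What is called first, only, known or untested is meant among the compounds shown, and "the series" means these compounds.

Compound 1 `CNc1nc(C)c(C(=O)N/N=C/c2cccc(C(F)(F)F)c2)s1` reaches only the limit of a functional assay on MCF7 cells (Homo sapiens) for inhibition, read by MTT assay, with a stated time of 72 h (a higher number here means a weaker inhibitor, a lower number a stronger inhibitor), giving > 100 ug/mL, which is a limit rather than a number. Among the measured compounds shown here, compound 2 `CN(C(=O)NC(=O)c1ccc([N+](=O)[O-])cc1)c1nc(C(F)(F)F)c(C(=O)N/N=C/c2ccc([N+](=O)[O-])cc2)s1` is the one compound with a measured number in this assay, where compound 2 gives 9.24 ug/mL. Compound 3 `CN(C(=O)NC(=O)c1ccc(Cl)c(Cl)c1)c1nc(C(F)(F)F)c(C(=O)N/N=C/c2ccc([N+](=O)[O-])cc2)s1` differs from compound 2 by 3,4-dichlorophenyl in place of 4-nitrophenyl on a carbonyl carbon. For the measured compounds named here, no measured step of this kind is available, so the size of the change from compound 2 to compound 3 is expected to be small, a 1.1-fold higher number from compound 2 to compound 3 (0.03 log units; within the scatter), with no clear direction beyond the usual scatter. Compound 3 is therefore estimated at 10 ug/mL in this assay, within a range from 3.5 ug/mL to 30 ug/mL.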

Compound 3, half-maximal inhibitory concentration: 6.74 ug/mL
The estimate for compound 3 lay 1.5-fold (0.17 log units) above the measured number, and the stated range covers the measured number.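

Setting 3,4-dichlorophenyl in place of 4-nitrophenyl on the carbonyl carbon gives, in this assay, a 1.4-fold lower number from compound 2 to compound 3 (0.14 log units; within the scatter). At this position the two groups therefore cannot be told apart in this assay, and the nitro group can be exchanged for two chlorine atoms without a change beyond the scatter. Nothing shown here explains this step.

The compounds shown leave open whether an unsubstituted phenyl, a cyclohexyl ring or a longer alkyl chain on this carbonyl carbon would behave alike. They also leave open how an amine or a carboxylic acid on the phenyl ring would fare.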